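A few compounds are considered here, and "the series" means these few. Any claim that something is new, unique, unknown or untested is made for them only; others in the source may bear on it.

Measured so far:
Compound 2 `O=C(CNC(=O)c1nn(-c2ccccc2)c(=O)c2ccccc12)Nc1nc2ccccc2s1`: 2600 nM
Compound 3 `COc1ccccc1-n1nc(C(=O)NCC(=O)Nc2nc3ccccc3s2)c2ccccc2c1=O`: 10000 nM
Compound 1 `COc1ccc(-n2nc(C(=O)NCC(=O)Nc3nc4ccccc4s3)c3ccccc3c2=O)cc1`: 25000 nM

In an assay on L cells for inhibition of Protein-serine O-palmitoleoyltransferase porcupine (Mus musculus), read by reporter gene assay, with a stated time of 24 h (a higher number here means that more compound is needed for the effect, a lower number that less compound is needed), compound 2 stands lowest of the three. Its nearest neighbour is compound 3, reached by a 3.8-fold higher number from compound 2 to compound 3 (0.59 log units; beyond the scatter), and compound 1 lies furthest away, as the step of a 9.6-fold lower number from compound 1 to compound 2 (0.98 log units; beyond the scatter) shows. Compound 4 `O=C(CNC(=O)c1nn(-c2ccccc2)c(=O)c2ccccc12)Nc1nc2ccc([N+](=O)[O-])cc2s1` differs from compound 2 by nitro in place of hydrogen on an aromatic carbon.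

Among the compounds with values here, none of the measured steps bears directly on this change: a 9.6-fold lower number from compound 1 to compound 2 (0.98 log units; beyond the scatter), a 2.5-fold lower number from compound 1 to compound 3 (0.40 log units; beyond the scatter) and a 3.8-fold higher number from compound 2 to compound 3 (0.59 log units; beyond the scatter) all alter the group on the aromatic nitrogen, while the 1,3-benzothiazol-2-yl end stays untouched in every measured compound. With no guide from the data, the expected outcome is no step beyond the scatter, no change at the digits printed from compound 2 to compound 4 (within the scatter), though a wide range is allowed. Compound 4 is therefore estimated at 2600 nM, between 700 nM and 10000 nM.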

Compound 4, half-maximal effective concentration: 240 nM
For compound 4 the middle estimate is 11-fold (1.03 log units) above the measured one, and the stated range ends above it.
By their numbers in this assay, from the lowest: compound 4; then compound 2; then compound 3; then compound 1.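

In this assay, the change from 1,3-benzothiazol-2-yl to 6-nitro-1,3-benzothiazol-2-yl gives an 11-fold lower number from compound 2 to compound 4 (1.03 log units; beyond the scatter). This shows that the end of the molecule left constant in compound 1, compound 2 and compound 3 also moves the number, and that compound 4 stands lowest of the four. Nothing available explains this step.

Going by these compounds, it remains open whether an amine, a nitrile or a fluorine on this aromatic carbon would act as nitro does. On these data alone, it also remains open whether nitro on another carbon of this ring would give a similar step.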